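Phenyl in Place of Bromo: Expected Cytotoxicity of Compound 3

The compounds below may be only part of what the source reports. "The series", "measured", "known", "first", "only" and "open" are said of these compounds alone.

Measured compounds:
Compound 1, `COc1ccc(CSc2nc(Cc3ccc(-c4ccccc4)cc3)c(C)c(=O)[nH]2)cc1`, 100000 nM
Compound 2, `CCc1c(Cc2ccc(Br)cc2)nc(SCc2ccc(OC)cc2)[nH]c1=O`, > 281000 nM

In an ADME assay on MT4 cells (Homo sapiens) for cytotoxicity, read by MTT assay (a lower number here means that less compound is tolerated, a higher number that more compound is tolerated), compound 1 gives 100000 nM. Compound 2 returns only a limit of the assay, > 281000 nM, so its cytotoxicity is known just as a bound the limit of > 281000 nM in this assay, at which 1 of the 2 values shown sits, and not as a number. Going by the values given here, no step between measured compounds is available here.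

Compound 3, `CCc1c(Cc2ccc(-c3ccccc3)cc2)nc(SCc2ccc(OC)cc2)[nH]c1=O`, has not yet been measured in this assay. It differs from compound 2 in one place: phenyl in place of bromo on an aromatic carbon. Compound 1 carries the same phenyl group and gives a number rather than a limit in this assay, while compound 2 carries the bromo group and gives only a limit.

Because the reference point for compound 2 is a limit (the limit of > 281000 nM in this assay, at which 1 of the 2 values shown sits), the expected step from compound 2 to compound 3 is estimated as an at least 2.8-fold lower number from compound 2 to compound 3 (0.44 log units; beyond the scatter), toward less compound being tolerated. Compound 3 is therefore expected at 100000 nM, with a range from 30000 nM to 300000 nM.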

Compound 3, half-maximal cytotoxic concentration: 194000 nM
Compound 3: middle estimate off by 1.9-fold (0.29 log units), on the low side; the measured number falls inside the stated range.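

In this assay, phenyl in place of bromo on an aromatic carbon gives an at least 1.4-fold lower number from compound 2 to compound 3 (0.16 log units; that floor lies within the scatter) and so puts a number where the bromo compound gave none. Methyl in place of hydrogen on a saturated chain carbon bound to an aromatic carbon gives a 1.9-fold higher number from compound 1 to compound 3 (0.29 log units; within the scatter) and thus shows no separable effect of that change in this assay. Compound 2 gives no number, only a limit of the assay: the limit of > 281000 nM in this assay, at which 1 of the 3 values shown sits.

Going by these compounds, how large the step from bromo to phenyl really is stays open without a number for compound 2. Also open, on these data alone, is how an amine or a carboxylic acid on that aromatic carbon, or a longer chain on the saturated chain carbon, would read in this assay.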